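Swapping methyl for methoxy on the benzyloxy arm

The compounds below may be only part of what the source reports. "The series", "measured", "known", "first", "only" and "open" are said of these compounds alone.

Three measured compounds share one core and differ only in the group placed on a saturated chain carbon bound to an oxygen on an aromatic ring. Compound 1 `FC(F)(F)c1ccc(CN2CCN(Cc3cc(-c4ccc(OCc5ccccc5)cc4)on3)CC2)cc1` carries phenyl there, and in a functional assay on MCF7 cells (Homo sapiens) for antiproliferative activity, read by sulforhodamine B assay, with a stated time of 72 h (on this read-out higher numbers stand for weaker inhibition and lower numbers for stronger inhibition), compound 1 gives 2900 nM. Compound 2 `Cc1cc(C)cc(COc2ccc(-c3cc(CN4CCN(Cc5ccc(C(F)(F)F)cc5)CC4)no3)cc2)c1` carries 3,5-dimethylphenyl, and in this assay compound 2 gives 1600 nM. Compound 3 `Fc1cccc(COc2ccc(-c3cc(CN4CCN(Cc5ccc(C(F)(F)F)cc5)CC4)no3)cc2)c1` carries 3-fluorophenyl, and in this assay compound 3 gives 2500 nM. Compound 2 holds the lowest of the three numbers, but both of its neighbours sit within the usual scatter: a 1.8-fold lower number from compound 1 to compound 2 (0.26 log units; within the scatter), and a 1.6-fold higher number from compound 2 to compound 3 (0.19 log units; within the scatter). Compound 4 `COc1cc(COc2ccc(-c3cc(CN4CCN(Cc5ccc(C(F)(F)F)cc5)CC4)no3)cc2)cc(OC)c1` has not yet been measured. 3,5-dimethoxyphenyl in place of 3,5-dimethylphenyl on a saturated chain carbon bound to an oxygen on an aromatic ring The two earlier exchanges at this same place stayed within the scatter, as did the fluoro step a 1.2-fold lower number from compound 1 to compound 3 (0.06 log units; within the scatter), so nothing in the data points to a shift beyond it. The step expected here, a 1.3-fold higher number from compound 2 to compound 4 (0.10 log units; within the scatter), is therefore none beyond the scatter. In this assay compound 4 is estimated at 2000 nM, with an expected range from 900 nM to 4500 nM.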

Compound 4, half-maximal inhibitory concentration: 100 nM
Compound 4: middle estimate off by 20-fold (1.30 log units), on the high side, outside the stated range (below it).
By their numbers in this assay, from the lowest: compound 4; then compounds 2, 3 and 1 (each within the scatter of the next).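

The saturated chain carbon bound to an oxygen on an aromatic ring had looked like an insensitive place, yet replacing 3,5-dimethylbenzyl with 3,5-dimethoxybenzyl gives a large change in this assay (a 16-fold lower number from compound 2 to compound 4 (1.20 log units; beyond the scatter)). Among these compounds, compound 4 also stands well apart from the other two compounds (a 25-fold lower number from compound 3 to compound 4 (1.40 log units; beyond the scatter); a 29-fold lower number from compound 1 to compound 4 (1.46 log units; beyond the scatter)), so the identity of the group at this place can matter greatly, which the earlier compounds did not reveal. The entering group brings oxygen atoms and hydrogen-bond acceptors that the leaving group lacks, but no measurement here explains the fall in the number.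

Going by these compounds, it remains open whether a single methoxy group would give the same result or both are required. On these data alone, the outcome with hydroxy groups or longer ethoxy chains on this ring also remains unknown.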